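Pyridyl to Phenyl Swap Repeated on a Second Core

The source may hold more compounds than are shown below. What is called first, only, known or untested is meant among the compounds shown, and "the series" means these compounds.

Compound 1 `O=C(Nc1cc(C(F)(F)F)ccc1Nc1ccc(Br)cc1)c1ccncc1` and compound 2 `O=C(Nc1cc(C(F)(F)F)ccc1Nc1ccc(Br)cc1)c1ccccc1` share one core, while compound 3 `CCN(CC)c1ccc(C(F)(F)F)cc1NC(=O)c1ccncc1` and compound 4 `CCN(CC)c1ccc(C(F)(F)F)cc1NC(=O)c1ccccc1` share another. In a functional assay on NALM-6 cells (Homo sapiens) for cytotoxicity, read by MTT assay, with a stated time of 48 h (a higher number here means a weaker inhibitor, a lower number a stronger inhibitor), compound 1 gives 51900 nM, compound 2 gives 6000 nM, and compound 3 gives 63600 nM. The two cores differ by diethylamino in place of (4-bromophenyl)amino on an aromatic carbon, a change that gave a 1.2-fold higher number from compound 1 to compound 3 (0.09 log units; within the scatter). Within the first core, the change phenyl in place of pyridin-4-yl on a carbonyl carbon produced an 8.7-fold lower number from compound 1 to compound 2 (0.94 log units; beyond the scatter). The same change is now made from compound 3 to compound 4, namely (phenyl in place of pyridin-4-yl on a carbonyl carbon), and the place is described in the same words both times; among the compounds shown it appears in these two pairs only. Because the first instance gave an 8.7-fold lower number from compound 1 to compound 2 (0.94 log units; beyond the scatter) and because compound 3 stands at 63600 nM, compound 4 is expected to reach 8000 nM, a step of an 8.0-fold lower number from compound 3 to compound 4 (0.90 log units; beyond the scatter) estimated from that single precedent. For the measured compounds named here, for compound 4 the expected lower and upper ends are 2500 nM and 25000 nM, a spread kept wide since only one measured pair supports the expectation.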

Compound 4, half-maximal inhibitory concentration: "not active" (no number reported)
Compound 4: no number reported; the estimate stays without a comparison.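

In this assay, for the compounds shown here, compound 4 is reported as "not active" with no number, so no step from compound 3 to compound 4 can be read. Nothing in the data bears on this result. The compounds shown leave open whether phenyl in place of pyridin-4-yl acts alike on both cores.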